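The source may report more compounds than this note shows. Statements on the series, on what has been measured and on what is new or still open speak of the compounds shown alone.

Compound 2 `COc1ccc(Nc2nc(-n3ccnc3C)cs2)cc1` is the anchor of this comparison. In a functional assay on RKO cells (Homo sapiens) for cytotoxicity, read by resazurin assay, with a stated time of 72 h (on this read-out higher numbers stand for weaker inhibition and lower numbers for stronger inhibition), compound 2 gives 1600 nM, the higher of the two numbers recorded in this assay, with compound 1 `Cc1ccc(Nc2nc(-n3ccnc3C)cs2)cc1` nearest at 450 nM. Among the compounds with values here, the step of a 3.6-fold higher number from compound 1 to compound 2 (0.55 log units; beyond the scatter) is the only measured change on the same aromatic carbon that compound 4 alters. Compound 3 `COc1ccc(Nc2nc(-n3ccnc3)cs2)cc1` reaches the limit of this assay, > 100000 nM. That value is the limit of > 100000 nM in this assay, at which 1 of the 3 values shown sits. The step of an at least 62-fold higher number from compound 2 to compound 3 (1.79 log units; beyond the scatter) concerns a different part of the molecule, one that compound 4 keeps unchanged, so it does not bear on the present step.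

Compound 4 `Cc1nccn1-c1csc(Nc2ccc(S(N)(=O)=O)cc2)n1` differs from compound 2 as follows: sulfamoyl in place of methoxy on an aromatic carbon. Within the data shown here, only the step from compound 1 to compound 2 informs this change, and there a swap of the group on that aromatic carbon moved the number by a modest amount. Among the measured compounds shown here, no measured pair shows the direction for sulfamoyl, so the expectation is a step of modest size, somewhat more likely toward a higher number than a lower one, with wide uncertainty. Compound 4 is therefore expected to give about 3000 nM in this assay, within a range from 700 nM to 15000 nM. The expected step is a 1.9-fold higher number from compound 2 to compound 4 (0.27 log units; within the scatter).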

Compound 4, half-maximal inhibitory concentration: 49000 nM
Compound 4: middle estimate off by 16-fold (1.21 log units), on the low side, outside the stated range (above it).
By their numbers in this assay, from the lowest: compound 1; then compound 2; then compound 4. At a limit, above all of these: compound 3.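

On the aromatic carbon para to a large group, sulfamoyl gives a 31-fold higher number from compound 2 to compound 4 (1.49 log units; beyond the scatter) in this assay, and the same comparison against methyl gives a 110-fold higher number from compound 1 to compound 4 (2.04 log units; beyond the scatter). Before this result, the only measured change at this carbon was the modest 3.6-fold higher number from compound 1 to compound 2 (0.55 log units; beyond the scatter), so compound 4 shows that this position can carry a large step and that, for sulfamoyl, the step runs toward a higher number, meaning weaker inhibition. The only measured fact offered alongside this result is the limit reached by compound 3, which concerns another part of the molecule, so nothing here accounts for the step.

The compounds shown leave open which feature of sulfamoyl goes with the higher number: a methylsulfonyl group would keep the sulfur and both oxygens without the nitrogen, while an amine or a carboxylic acid on the same carbon would test other replacements for methoxy. They also leave open whether a small group such as fluorine or chlorine would stay close to compound 1 and compound 2, or whether methyl and methoxy are unusually well tolerated at this carbon.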